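The compounds below may be only part of what the source reports. "The series", "measured", "known", "first", "only" and "open" are said of these compounds alone.

In a functional assay for inhibition of sodium/hydrogen exchanger (Oryctolagus cuniculus) (a higher number here means a weaker inhibitor, a lower number a stronger inhibitor), three compounds sharing one core have been measured. Compound 1 `Cc1cc(SC(C)C)c(S(C)(=O)=O)cc1C(=O)N=C(N)N` gives 12 nM, compound 2 `Cc1cc(SC(C)(C)C)c(S(C)(=O)=O)cc1C(=O)N=C(N)N` gives 22 nM, and compound 3 `Cc1cc(Sc2cccc(Cl)c2)c(S(C)(=O)=O)cc1C(=O)N=C(N)N` gives 37 nM, the highest number of the three, though its gap to compound 2 is within the scatter.

Compound 4 `CCOc1cc(C)c(C(=O)N=C(N)N)cc1S(C)(=O)=O` differs from compound 3 in one place: ethoxy in place of (3-chlorophenyl)sulfanyl on an aromatic carbon. The measured steps all vary the group on the sulfur: a 1.8-fold higher number from compound 1 to compound 2 (0.26 log units; within the scatter); a 3.1-fold higher number from compound 1 to compound 3 (0.49 log units; beyond the scatter); a 1.7-fold higher number from compound 2 to compound 3 (0.23 log units; within the scatter). Going by the values given here, the only step beyond the scatter shows that a smaller saturated group on the sulfur goes with a lower number than the 3-chlorophenyl group. Ethoxy is again small, but none of the measured compounds tests removing the sulfur itself, so the change is only partly covered.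

Compound 4 is therefore expected to move back toward the lower numbers, an estimated 1.9-fold lower number from compound 3 to compound 4 (0.27 log units; within the scatter), giving an estimate for compound 4 of 20 nM, in a range from 6 nM to 70 nM.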

Compound 4, half-maximal inhibitory concentration: 19 nM
Compound 4: middle estimate off by 1.1-fold (0.02 log units), on the high side; the measured number falls inside the stated range.
By their numbers in this assay, from the lowest: compounds 1, 4, 2 and 3 (each within the scatter of the next, the first and the last beyond it).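

Going by these compounds alone, compound 4 is the first compound here without a sulfur on this aromatic carbon, and in this assay ethoxy stays within the scatter of all three sulfur compounds: a 1.9-fold lower number from compound 3 to compound 4 (0.29 log units; within the scatter) and a 1.2-fold lower number from compound 2 to compound 4 (0.06 log units; within the scatter) and a 1.6-fold higher number from compound 1 to compound 4 (0.20 log units; within the scatter) are the steps. At this position, ortho to a methylsulfonyl group, the sulfur is therefore not needed to keep the number in the range seen so far, and ethoxy with 3 heavy atoms and no ring cannot be told apart from (3-chlorophenyl)sulfanyl with 8 heavy atoms and a ring. No supporting measurement is available to explain this result.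

The compounds shown cannot say how much of this depends on the oxygen and how much on the chain attached to it. Isopropoxy, which would pair directly with the isopropylsulfanyl group of compound 1, or an amine on this carbon would help separate the two.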